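The compounds below may be only part of what the source reports. "The series", "measured", "known", "first", "only" and "open" are said of these compounds alone.

Values in an ADME assay on BJ cells (Homo sapiens) for cytotoxicity, read by luminescence, with a stated time of 72 h (on this read-out higher numbers stand for an effect only at larger amounts of compound and lower numbers for an effect already at smaller amounts), follow. Each is a limit of the assay and not a number.

- Compound 1 `CCOC(=O)c1c(-c2cccc(OC)c2)[nH]c2cc(OC)ccc2c1=O`: > 21500 nM
- Compound 2 `CCCCOc1cccc(-c2[nH]c3cc(OC)ccc3c(=O)c2C(=O)OCC)c1`: > 21500 nM
- Compound 3 `CCOC(=O)c1c(-c2cccc(Oc3ccccc3)c2)[nH]c2cc(OC)ccc2c1=O`: > 21500 nM

Compound 3 has only a limit, > 21500 nM, so it cannot be ranked against compound 1 or compound 2.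

Compound 4 `CCOC(=O)c1c(-c2cccc(F)c2)[nH]c2cc(OC)ccc2c1=O` carries fluoro in place of phenoxy on an aromatic carbon, meta to a large group: fluoro in place of phenoxy on an aromatic carbon.

The measured steps at this place are a step that the two limits leave unreadable from compound 1 to compound 2, a step that the two limits leave unreadable from compound 1 to compound 3 and a step that the two limits leave unreadable from compound 2 to compound 3. None of them has a readable size, and each keeps an oxygen on the aromatic ring, which the change to fluoro does not. They therefore give no direction for this assay, and no step beyond the scatter is expected.

Compound 4 is expected to give a limit as well, because of the limit of > 21500 nM in this assay, at which 3 of the 3 values shown sit.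

The expected step is a step that the limit leaves unreadable from compound 3 to compound 4, and its direction cannot be read.

Compound 4 is estimated at 25000 nM, with an expected range from 12000 nM to 40000 nM.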

Compound 4, half-maximal effective concentration: > 21500 nM
Compound 4: no number, only a limit; the forecaster's own chance of this, stated with the estimate: 85%; the middle value lies beyond the limit too.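

Among these compounds, compound 4 sits at a limit in this assay, as do compounds 1, 2 and 3, so no step among the four can be read: the limit of > 21500 nM in this assay, at which 4 of the 4 values shown sit.

The compounds shown leave open at what concentration any of the four would show an effect, and whether fluoro, methoxy, butoxy and phenoxy differ at all.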